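A few compounds are considered here, and "the series" means these few. Any claim that something is new, unique, unknown or untested is made for them only; others in the source may bear on it.

Measured in a functional assay on A-375 cells (Homo sapiens) for cytotoxicity, read by MTT assay, with a stated time of 24 h; on this read-out lower numbers stand for stronger inhibition and higher numbers for weaker inhibition:
- compound 1 `COc1cc(C)cc2c1C(=O)C=C(c1c(C)cc3c(c1OC)C(=O)C(Nc1ccc4ccccc4c1)=CC3=O)C2=O`: 80 nM
- compound 2 `COc1cc(C)cc2c1C(=O)C=C(c1c(C)cc3c(c1OC)C(=O)C(NCc1ccccc1)=CC3=O)C2=O`: 550 nM
- compound 3 `CCOC(=O)CNC1=CC(=O)c2cc(C)c(C3=CC(=O)c4c(OC)cc(C)cc4C3=O)c(OC)c2C1=O`: 570 nM

Compound 3 sits at the high end of these numbers, but it shares that end with another compound: the measurements show a 1.0-fold higher number from compound 2 to compound 3 (0.02 log units; within the scatter). Compound 1, with naphthalen-2-yl on the amine nitrogen, stands apart. The data show a 6.9-fold higher number from compound 1 to compound 2 (0.84 log units; beyond the scatter) and a 7.1-fold higher number from compound 1 to compound 3 (0.85 log units; beyond the scatter), both modest.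

The next compound, compound 4 `COc1cc(C)cc2c1C(=O)C=C(c1c(C)cc3c(c1OC)C(=O)C(N)=CC3=O)C2=O`, has not yet been measured. It loses the whole side chain: hydrogen in place of (ethoxycarbonyl)methyl on an amine nitrogen. The result is hydrogen in place of (ethoxycarbonyl)methyl on an amine nitrogen. Among the measured compounds shown here, no measured compound carries this bare amino group, so the evidence is indirect. Compound 4 also lacks naphthalen-2-yl, and the two measured compounds without that group gave matching numbers, so it is expected to stay near them. The expected change is a 1.1-fold higher number from compound 3 to compound 4 (0.02 log units; within the scatter), so no step beyond the scatter is expected, and no direction can be favoured. Compound 4 is estimated at 600 nM, with an expected range of 200 nM to 2000 nM.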

Compound 4, half-maximal inhibitory concentration: 3240 nM
The estimate for compound 4 lay 5.4-fold (0.73 log units) below the measured number; the whole stated range lies below it.
By their numbers in this assay, from the lowest: compound 1; then compounds 2 and 3 (each within the scatter of the next); then compound 4.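

In this assay the amine nitrogen turns out to matter even for the side chains that looked alike: hydrogen in place of (ethoxycarbonyl)methyl gives a 5.7-fold higher number from compound 3 to compound 4 (0.75 log units; beyond the scatter) and hydrogen in place of benzyl gives a 5.9-fold higher number from compound 2 to compound 4 (0.77 log units; beyond the scatter) in the same direction. The loss is larger when the bare amino group is set against naphthalen-2-yl, with a 41-fold higher number from compound 1 to compound 4 (1.61 log units; beyond the scatter) on that step, so all three substituents shown give lower numbers than compound 4, and the match between compound 2 and compound 3 does not simply reflect the shared core. No measurement shown here bears on the reason for these steps.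

Going by these compounds, how small a group on this nitrogen can be and still give the lower numbers stays open. A methyl group or an acetyl group there could fall nearer to benzyl or nearer to hydrogen.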